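Swapping the Amine on the Shared Core

The source may report more compounds than this note shows. Statements on the series, on what has been measured and on what is new or still open speak of the compounds shown alone.

Compound 1 `Nc1nc(OCC(F)(F)F)c2ncn(/C=C3/CC3(CO)CO)c2n1` and compound 2 `CN(C)c1nc(N)nc2c1ncn2/C=C1/CC1(CO)CO` share one core and differ in a single group on an aromatic carbon. In an ADME assay on BCBL1 cells (Homo sapiens) for cytotoxicity, with a stated time of 7 days (a higher number here means that more compound is tolerated, a lower number that less compound is tolerated), compound 1 gives > 20000 nM, which is a limit of the assay and not a number. In this assay compound 2 likewise gives > 20000 nM, again a limit. The step that the two limits leave unreadable from compound 1 to compound 2 is therefore unreadable in size. Compound 3 `Nc1nc(NC2CCCC2)c2ncn(/C=C3/CC3(CO)CO)c2n1` has not been measured; its change is cyclopentylamino in place of dimethylamino on an aromatic carbon. For the measured compounds named here, no measured step covers this change, and both measured values sit at the limit of > 20000 nM in this assay, at which 2 of the 2 values shown sit. Compound 3 is therefore expected to show a step that the limit leaves unreadable from compound 2 to compound 3, with an estimated value of 25000 nM, between 10000 nM and 60000 nM.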

Compound 3, half-maximal cytotoxic concentration: 71700 nM
Compound 3: the middle estimate sits 2.9-fold (0.46 log units) below what was measured; the whole stated range lies below it.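

For the compounds shown here, no step from compound 1 or compound 2 to compound 3 can be read in this assay, because compound 1 and compound 2 each give a limit and not a number: the limit of > 20000 nM in this assay, at which 2 of the 3 values shown sit. As far as these compounds go, how far swapping the group on the aromatic carbon shifts the tolerated concentration stays open.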